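Swapping the piperidine for methylpiperazine on the shared core

The compounds below may be only part of what the source reports. "The series", "measured", "known", "first", "only" and "open" are said of these compounds alone.

In a functional assay on CHO-K1 cells for antagonist activity at transient receptor potential cation channel subfamily V member 1 (Homo sapiens), read by FLIPR (on this read-out higher numbers stand for weaker inhibition and lower numbers for stronger inhibition), compound 2 `CC(C(=O)NCc1ccc(C(F)(F)F)nc1N1CCC(CN(C)C)CC1)c1ccc(NS(C)(=O)=O)c(F)c1` gives 2.1 nM, the higher of the two numbers measured; compound 1 `CC(C(=O)NCc1ccc(C(F)(F)F)nc1N1CCC(C(F)(F)F)CC1)c1ccc(NS(C)(=O)=O)c(F)c1` gives 0.6 nM. Among the measured compounds shown here, the single measured step, a 3.5-fold higher number from compound 1 to compound 2 (0.54 log units; beyond the scatter), changed a substituent on the saturated ring rather than the ring itself. Compound 3 `CC(C(=O)NCc1ccc(C(F)(F)F)nc1N1CCN(C)CC1)c1ccc(NS(C)(=O)=O)c(F)c1` carries 4-methylpiperazin-1-yl in place of 4-((dimethylamino)methyl)piperidin-1-yl on an aromatic carbon. For the measured compounds named here, no measured step matches this change, and the one step in hand is modest, so a modest move toward a higher number, or none beyond the scatter, is expected, giving a 1.9-fold higher number from compound 2 to compound 3 (0.28 log units; within the scatter). Compound 3 is estimated at 4 nM, within 1 nM to 15 nM.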

Compound 3, inhibition constant: 146 nM
The estimate for compound 3 lay 37-fold (1.56 log units) below the measured number; the whole stated range lies below it.
By their numbers in this assay, from the lowest: compound 1; then compound 2; then compound 3.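

Swapping the group on the aromatic carbon next to the ring nitrogen matters far more than changing a substituent on the saturated ring: 4-methylpiperazin-1-yl in place of 4-((dimethylamino)methyl)piperidin-1-yl gives a 70-fold higher number from compound 2 to compound 3 (1.84 log units; beyond the scatter), a large step. Placed against 4-(trifluoromethyl)piperidin-1-yl, the same group gives a 240-fold higher number from compound 1 to compound 3 (2.39 log units; beyond the scatter), also large.

No available evidence bears on the cause of this shift. Open, going by these compounds, is whether a morpholine or an unsubstituted piperazine here would read nearer compound 2 or compound 3.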